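The compounds below may be only part of what the source reports. "The series", "measured", "known", "first", "only" and "open" are said of these compounds alone.

Working notes on the series. Of the compounds shown here, two are measured so far: compound 1 `Cc1cc(Cl)ccc1C(=O)N(C)c1cccnc1` and compound 2 `O=C1c2ccc(Cl)cc2CN1c1cccnc1`. In an assay on cells for inhibition of cytochrome P450 11B2, mitochondrial (Homo sapiens), read by HTRF (on this read-out higher numbers stand for weaker inhibition and lower numbers for stronger inhibition), compound 1 returns only a limit, > 3000 nM, and not a number; this is the reading recorded under (the limit of > 3000 nM in this assay, at which 1 of the 2 values shown sits). Among the compounds with values here, compound 2 gives 179 nM in this assay, which is the only actual number in the set. Compound 2 therefore stands alone as the reference point for the next step.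

The next compound follows from compound 2. Compound 3 `O=C1c2ccccc2CN1c1cccnc1` differs from compound 2 by hydrogen in place of chloro on an aromatic carbon. Within the data shown here, no step between two measured compounds is available to calibrate this change, so the expectation rests on the structural change alone. Removal of the chloro from the fused core of compound 2 is expected to weaken inhibition somewhat in this assay, an estimated step of a 2.5-fold higher number from compound 2 to compound 3 (0.40 log units; beyond the scatter), modest rather than large. Compound 3 is estimated at 450 nM in this assay, with a range from 150 nM to 1400 nM.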

Compound 3, half-maximal inhibitory concentration: 1120 nM
Estimate against measurement, compound 3: 2.5-fold (0.40 log units) below, and the stated range covers the measured number.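

In this assay, hydrogen in place of chloro on this aromatic carbon gives a 6.3-fold higher number from compound 2 to compound 3 (0.80 log units; beyond the scatter), so inhibition in this pair depends on what sits at this position. Within the data shown here, this is the first step between two measured compounds that differ in one place, and it gives a first calibrated size for a change on this carbon, though it rests on this single pair and supports no wider pattern. The measurements shown do not bear on why the loss of chloro goes with weaker inhibition.

Still open, going by these compounds, is whether another group on this carbon, such as fluoro, methoxy, a nitrile or an amine, would match chloro, fall back towards hydrogen or go beyond chloro. Also open is whether chloro on a different aromatic carbon of the shared core would give a step of similar size, as the compounds shown hold chloro at only this one place on that core.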